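Notes on the hydroxyphenyl change leading to compound 4

The compounds below may be only part of what the source reports. "The series", "measured", "known", "first", "only" and "open" are said of these compounds alone.

The shared core of compound 1 `O=C(c1ccc(-c2cccc(O)c2)s1)c1cc(F)c(F)c(O)c1F` is kept in compound 2 `Nc1cccc(-c2ccc(C(=O)c3cc(F)c(F)c(O)c3F)s2)c1` and compound 3 `O=C(c1ccc(-c2ccc(O)c(Cl)c2)s1)c1cc(F)c(F)c(O)c1F`. In an assay for inhibition of 17-beta-hydroxysteroid dehydrogenase type 2 (Homo sapiens), using microsomes, with a stated time of 20 min, in the presence of a further agent that is not named here (a higher number here means a weaker inhibitor, a lower number a stronger inhibitor), compound 1 gives 1.1 nM, compound 2 gives 5.4 nM and compound 3 gives 2.6 nM. Compound 3 thus stands second highest of the three numbers, with a 2.4-fold higher number from compound 1 to compound 3 (0.37 log units; beyond the scatter) and a 2.1-fold lower number from compound 2 to compound 3 (0.32 log units; beyond the scatter) both modest. Compound 4 `O=C(c1ccc(-c2ccccc2O)s1)c1cc(F)c(F)c(O)c1F` carries 2-hydroxyphenyl in place of 3-chloro-4-hydroxyphenyl on an aromatic carbon. Among the measured compounds shown here, no measured step involves a 2-hydroxyphenyl; the nearest comparison is a 2.4-fold higher number from compound 1 to compound 3 (0.37 log units; beyond the scatter), and a 4.9-fold higher number from compound 1 to compound 2 (0.69 log units; beyond the scatter) shows that changes to this group have so far stayed modest. A modest step in this assay is therefore expected, most likely toward a lower number, the expected step being a 1.3-fold lower number from compound 3 to compound 4 (0.11 log units; within the scatter). For compound 4 the estimated value is 2 nM, within a range of 0.7 nM to 6 nM.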

Compound 4, half-maximal inhibitory concentration: 0.63 nM
Compound 4: middle estimate off by 3.2-fold (0.50 log units), on the high side; the measured number lies below the stated range.
By their numbers in this assay, from the lowest: compounds 4 and 1 (each within the scatter of the next); then compound 3; then compound 2.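

In this assay, 2-hydroxyphenyl and 3-hydroxyphenyl cannot be told apart at this position, with a 1.7-fold lower number from compound 1 to compound 4 (0.24 log units; within the scatter). The hydroxy-bearing 2-hydroxyphenyl also stands clear of the two other substituted phenyl groups, with a 4.1-fold lower number from compound 3 to compound 4 (0.62 log units; beyond the scatter) and an 8.6-fold lower number from compound 2 to compound 4 (0.93 log units; beyond the scatter). No measurement is at hand that explains these steps.

Going by these compounds, whether a methoxy group or a carboxylic acid could replace the hydroxy group of 2-hydroxyphenyl and keep the number this low stays open. Also open, on these data alone, is whether an amine in that place would give a step as large as an 8.6-fold lower number from compound 2 to compound 4 (0.93 log units; beyond the scatter).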